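Dimethylated Oxolane in Place of the Plain Ring

A few compounds are considered here, and "the series" means these few. Any claim that something is new, unique, unknown or untested is made for them only; others in the source may bear on it.

Of the compounds shown here, two have been measured in an assay on isolated protein for inhibition of activin receptor type-2A (Homo sapiens), read by 33P incorporation, with a stated time of 20 min, in the presence of a further agent that is not named here; a lower number here means a stronger inhibitor, a higher number a weaker inhibitor. Compound 1 `COc1cc(-c2cnn3cc(OC)c(C4CCOC4)nc23)ccn1` gives 1900 nM, and compound 2 `Cn1cc(-c2nc3c(-c4ccnc(OC5CC5)c4)cnn3cc2OCCCC(C)(C)O)cn1` gives 2900 nM. These two values lie within the scatter of each other, so neither stands apart from the other. Compound 3 `COc1cc(-c2cnn3cc(OC)c([C@H]4COC(C)(C)C4)nc23)ccn1` has not yet been measured. It differs from compound 1 in one place: a group of 7 heavy atoms (6 carbon, 1 oxygen; one five-membered non-aromatic ring with 1 hetero atom) in place of a group of 5 heavy atoms (4 carbon, 1 oxygen; one five-membered non-aromatic ring with 1 hetero atom), on an aromatic carbon. Within the data shown here, no measured pair shows this change. The step of a 1.2-fold lower number from compound 1 to compound 3 (0.07 log units; within the scatter) is expected to stay within the scatter, in no clear direction. Compound 3 is estimated at 1600 nM, with a range from 500 nM to 5000 nM.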

Compound 3, half-maximal inhibitory concentration: 4100 nM
Compound 3: middle estimate off by 2.6-fold (0.41 log units), on the low side, within the range that was stated.
By their numbers in this assay, from the lowest: compounds 1, 2 and 3 (each within the scatter of the next, the first and the last beyond it).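

In this assay, among these compounds, replacing the oxolan-3-yl group on this aromatic carbon with the dimethylated ring of 7 heavy atoms brings a 2.2-fold higher number from compound 1 to compound 3 (0.33 log units; beyond the scatter), the first measured step at this position. The added carbons do not help here, although the single defined stereocentre enters in the same step, so the two features cannot be told apart. Nothing available explains the loss. As far as these compounds go, it remains open how the opposite stereoisomer would behave, and how a piperidine ring, which carries an amine, would fare at this position.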